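Pyrazole substituent swap and cytotoxicity in the urea series

The source may report more compounds than this note shows. Statements on the series, on what has been measured and on what is new or still open speak of the compounds shown alone.

Compound 1 `O=C1CC(c2cnco2)CN1c1cnn2c1CN(C(=O)Nc1cc(F)c(F)c(F)c1)C(C1CC1)C2` gives 139000 nM in a toxicity assay on HepG2 2.2.15 cells (Homo sapiens) for cytotoxicity, read by CellTiter-Glo; on this read-out lower numbers stand for higher toxicity in this test and higher numbers for lower toxicity in this test. Compound 2 `CC1(C)CC(=O)N(c2cnn3c2CN(C(=O)Nc2cc(F)c(F)c(F)c2)C(C2CC2)C3)C1` gives 115000 nM in this assay. Compound 3 `Cc1nc(C2CC(=O)N(c3cnn4c3CN(C(=O)Nc3cc(F)c(F)c(F)c3)C(C3CC3)C4)C2)no1` returns only a limit of the assay in this assay, namely > 200000 nM, so its exact position on the scale is not known (the limit of > 200000 nM in this assay, at which 1 of the 3 values shown sits). The measured steps of a 1.2-fold lower number from compound 1 to compound 2 (0.08 log units; within the scatter), an at least 1.4-fold higher number from compound 1 to compound 3 (0.15 log units; that floor lies within the scatter) and an at least 1.7-fold higher number from compound 2 to compound 3 (0.24 log units; that floor lies within the scatter) all lie within the scatter. Compound 4 `O=C(Nc1cc(F)c(F)c(F)c1)N1Cc2c(-c3ccc(F)cc3)cnn2CC1C1CC1` is not yet measured; it differs from compound 3 by 4-fluorophenyl in place of 4-(5-methyl-1,2,4-oxadiazol-3-yl)-2-oxopyrrolidin-1-yl on an aromatic carbon. For the measured compounds named here, none of the measured steps exchanges the whole substituent on that aromatic carbon for a carbon-only aromatic ring, so they bear on it only loosely; the three measured compounds sit close together, and no step beyond the scatter in this assay is expected. Compound 4 is estimated at 150000 nM, between 50000 nM and 250000 nM. The expected step is an at least 1.3-fold lower number from compound 3 to compound 4 (0.12 log units; that floor lies within the scatter).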

Compound 4, half-maximal cytotoxic concentration: 38500 nM
Estimate against measurement, compound 4: 3.9-fold (0.59 log units) above; measured number outside the range, below it.
By their numbers in this assay, from the lowest: compound 4; then compounds 2 and 1 (each within the scatter of the next). At a limit, above all of these: compound 3.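

Among the compounds shown, only the exchange for 4-fluorophenyl on this aromatic carbon gives steps beyond the scatter in this assay: a 3.0-fold lower number from compound 2 to compound 4 (0.48 log units; beyond the scatter), and a 3.6-fold lower number from compound 1 to compound 4 (0.56 log units; beyond the scatter). The third step, an at least 5.1-fold lower number from compound 3 to compound 4 (0.71 log units; beyond the scatter), gives only a floor. Compound 3 stands at a limit of the assay: the limit of > 200000 nM in this assay, at which 1 of the 4 values shown sits.

Going by these compounds, whether the lower number follows the carbon-only aromatic ring itself or its fluorine stays open. Unsubstituted phenyl and pyridyl on this carbon would separate the two.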